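Bromo on the shared core: notes on the series

The source may hold more compounds than are shown below. What is called first, only, known or untested is meant among the compounds shown, and "the series" means these compounds.

Of the compounds shown here, two have been measured so far, both in a functional assay on HeLa cells (Homo sapiens) for cytotoxicity, read by MTT assay, with a stated time of 24 h; on this read-out higher numbers stand for weaker inhibition and lower numbers for stronger inhibition. Compound 1 `O=c1nc2ccccn2cc1Cc1ccc(F)cc1` gives 139000 nM. Compound 2 `O=c1nc2ccccn2cc1Cc1ccccc1` gives > 1000000 nM, which is a limit of the assay and not a number.

Compound 3 `O=c1nc2ccccn2cc1Cc1ccc(Br)cc1` follows from compound 2 by one change: bromo in place of hydrogen on an aromatic carbon. In words, this is bromo in place of hydrogen on an aromatic carbon of a six-membered aromatic ring of carbon only, para to a large group.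

Within the data shown here, one measured step bears on this change, the loss of fluoro on going to compound 2: an at least 7.1-fold higher number from compound 1 to compound 2 (0.85 log units; beyond the scatter). Read in reverse, that step suggests a halogen on compound 2 should lower the number by more than the scatter, although bromo itself is untested. With only a limit for compound 2, the size of the step has no firm starting point. Compound 1 at 139000 nM is the better anchor.

The expected change is an at least 10-fold lower number from compound 2 to compound 3 (1.00 log units; beyond the scatter), toward stronger inhibition. Compound 3 is estimated at 100000 nM, with an expected range of 30000 nM to 350000 nM.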

Compound 3, half-maximal inhibitory concentration: > 1000000 nM
Compound 3: a limit, no number; the forecaster's own chance of this, stated with the estimate: 10%; middle value at least 10-fold (1.00 log units) away from the limit.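

This result shows that a halogen at this place, on an aromatic carbon para to a large group, does not by itself give a readable value in this assay, and that the two halogens tested are not interchangeable: bromo in place of fluoro gives an at least 7.1-fold higher number from compound 1 to compound 3 (0.85 log units; beyond the scatter). Of the three compounds, only compound 1 gives a number, at 139000 nM, so the readable activity in this small set rests on fluoro alone and not on halogen substitution as a class. The step from compound 2 to compound 3 cannot be read, because both compounds stand at the same limit of the assay, and nothing can be said about whether bromo in place of hydrogen changes the number at all: the limit of > 1000000 nM in this assay, at which 2 of the 3 values shown sit.

From the compounds shown here alone, it remains open whether the value seen with fluoro extends to chloro, or to non-halogen groups at the same place such as methoxy, an amine or a carboxylic acid. Also open, going by these compounds, is where the true values of compound 2 and compound 3 lie, so no order can be given for these two.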